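This account rests on a few compounds, and the source may have more. Where it says the series, first, only, none or still open, it means among the compounds named here.

Compound 1 `CCO/N=C(\C)CCN1CCN(c2nc(=O)c3cc(C(F)(F)F)cc([N+](=O)[O-])c3s2)CC1`: > 64 ug/mL
Compound 2 `CCON=C1CCC(CN2CCN(c3nc(=O)c4cc(C(F)(F)F)cc([N+](=O)[O-])c4s3)CC2)CC1`: > 64 ug/mL

In an ADME assay on Vero cells (Chlorocebus sabaeus) for cytotoxicity (a higher number here means that more compound is tolerated, a lower number that less compound is tolerated), compound 1 gives > 64 ug/mL, which is a limit of the assay rather than a number. In this assay compound 2 gives > 64 ug/mL, likewise a limit. Both measurements sit at the limit of > 64 ug/mL in this assay, at which 2 of the 2 values shown sit, so the step that the two limits leave unreadable from compound 1 to compound 2 cannot be sized. Compound 3 `CCON=C1CC(CN2CCN(c3nc(=O)c4cc(C(F)(F)F)cc([N+](=O)[O-])c4s3)CC2)C1` differs from compound 2 by a group of 8 heavy atoms (6 carbon, 1 nitrogen, 1 oxygen; one four-membered non-aromatic ring of carbon only) in place of a group of 10 heavy atoms (8 carbon, 1 nitrogen, 1 oxygen; one six-membered non-aromatic ring of carbon only), on a saturated chain carbon bound to an amine nitrogen in a ring. Going by the values given here, no measured step of readable size bears on this change, and compound 2 itself stands only at a limit. Compound 3 is expected to give 100 ug/mL, within 50 ug/mL to 200 ug/mL. The expected step that the limit leaves unreadable from compound 2 to compound 3 is none beyond the scatter.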

Compound 3, half-maximal cytotoxic concentration: > 64 ug/mL
Compound 3: no number, only a limit; the forecaster's own chance of this, stated with the estimate: 80%; the middle value is on the limit's open side.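

Compound 3 also gives a limit rather than a number, so the steps among compound 1, compound 2 and compound 3 cannot be read: the limit of > 64 ug/mL in this assay, at which 3 of the 3 values shown sit. Going by these compounds, whether these side groups differ at all in this assay stays open.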